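This account rests on a few compounds, and the source may have more. Where it says the series, first, only, none or still open, it means among the compounds named here.

Among the compounds with values here, the three compounds measured so far share one core. Compound 1 `CN1CCCC(NS(=O)(=O)c2ccccc2Nc2cc(-c3ccc4ccn(C)c4c3)c3nccnc3c2)C1` gives 59 nM in an assay for inhibition of 6-phosphofructo-2-kinase/fructose-2,6-bisphosphatase 3 (Homo sapiens), read by ADP-Glo, with a stated time of 2 h; a higher number here means a weaker inhibitor, a lower number a stronger inhibitor. Within the data shown here, compound 2 `CN(Cc1cncnc1)S(=O)(=O)c1ccccc1Nc1cc(-c2ccc3ccn(C)c3c2)c2nccnc2c1` gives 62 nM in this assay, and the single step recorded between measured compounds, a 1.1-fold higher number from compound 1 to compound 2 (0.02 log units; within the scatter), replaces only the amine on the sulfonyl sulfur. Compound 3 `CN1CCC(NC(=O)c2ccncc2Nc2cc(-c3ccc4ccn(C)c4c3)c3nccnc3c2)CC1` carries an amide where the others carry a sulfonamide and gives 38 nM in this assay; this is the lowest of the three numbers, but its gaps to compound 1 and to compound 2 both lie within the scatter, so the three values cannot be told apart.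

Compound 4 `CC(=O)N1CCOC(CNC(=O)c2ccncc2Nc2cc(-c3ccc4ccn(C)c4c3)c3nccnc3c2)C1` differs from compound 3 in one place: (4-acetylmorpholin-2-yl)methyl in place of 1-methylpiperidin-4-yl on an amide-type nitrogen. Among the measured compounds shown here, no measured step touches an amide nitrogen directly. For the measured compounds named here, the one step available, a 1.1-fold higher number from compound 1 to compound 2 (0.02 log units; within the scatter), exchanged a ring amine for an open-chain one on a sulfonyl sulfur without moving the number beyond the scatter, and compound 1, compound 2 and compound 3 sit within the scatter of one another despite differing in that same region. On this basis the step is expected to be a 1.3-fold higher number from compound 3 to compound 4 (0.12 log units; within the scatter), nothing beyond the scatter. Compound 4 is estimated at 50 nM, with a range from 15 nM to 170 nM.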

Compound 4, half-maximal inhibitory concentration: 93 nM
The estimate for compound 4 lay 1.9-fold (0.27 log units) below the measured number; the range from low to high includes it.
By their numbers in this assay, from the lowest: compounds 3, 1, 2 and 4 (each within the scatter of the next, the first and the last beyond it).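

On an amide-type nitrogen, (4-acetylmorpholin-2-yl)methyl in place of 1-methylpiperidin-4-yl gives the first step among these compounds to pass beyond the scatter in this assay (a 2.4-fold higher number from compound 3 to compound 4 (0.39 log units; beyond the scatter)), whereas the one earlier step, on a sulfonyl sulfur, stayed within it (a 1.1-fold higher number from compound 1 to compound 2 (0.02 log units; within the scatter)). The position therefore does respond to the group it carries, although the step is modest and runs towards a weaker inhibitor, and this single change brings in several differences at once: a second hetero atom in the ring, an acetyl group with its double bond outside aromatic rings, and a methyl link between the ring and the nitrogen. No measurement shown here accounts for the step.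

Which of these differences carries the step stays open, and (1-methylpiperidin-4-yl)methyl or (morpholin-2-yl)methyl without the acetyl group on the same nitrogen would begin to separate them. From the compounds shown here alone, whether the same exchange would behave alike on the sulfonyl sulfur of compound 1 also stays open, as does the effect of a longer chain or a carboxylic acid at this place.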